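Carbamoyl in Place of Cyano: an Expected Solubility Step

A few compounds are considered here, and "the series" means these few. Any claim that something is new, unique, unknown or untested is made for them only; others in the source may bear on it.

Compound 1, `O=C(Nc1ccc(F)c(C(F)(F)F)c1)Nc1ccccn1`, gives only a limit in a physicochemical assay for solubility, read by nephelometry, in phosphate buffer, measured as kinetic solubility, at pH 6.5 (a lower number here means a less soluble compound, a higher number a more soluble compound), namely < 1.6 ug/mL.
Compound 2, `O=C(Nc1cccc(C(=O)O)c1)Nc1ccc(F)c(C(F)(F)F)c1`, gives 12.5 ug/mL in this assay.
Compound 3, `N#Cc1ccc(NC(=O)Nc2ccc(F)c(C(F)(F)F)c2)cc1`, gives only a limit in this assay, namely < 1.6 ug/mL.

Compound 3 therefore stands at the floor of the three values shown; two of the three values shown sit at the limit of < 1.6 ug/mL in this assay, at which 2 of the 3 values shown sit, and only compound 2 gives a number above it. No pair of these compounds differs in one place, so no measured step can be read from them.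

The compound not yet measured is compound 4, `NC(=O)c1ccc(NC(=O)Nc2ccc(F)c(C(F)(F)F)c2)cc1`. It differs from compound 3 as follows: carbamoyl in place of cyano on an aromatic carbon.

Because compound 3 gives only a limit, < 1.6 ug/mL, the step from it cannot be anchored to a number. The account expects the step from compound 3 to compound 4 in this assay to be modest and upward, an at least 2.1-fold higher number from compound 3 to compound 4 (0.33 log units; beyond the scatter), with a fair chance that compound 4 again returns only a limit rather than a number. The estimate for compound 4 in this assay is 3.5 ug/mL, with a range from 1.6 ug/mL to 10 ug/mL.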

Compound 4, solubility: 6.3 ug/mL
Compound 4: the middle estimate sits 1.8-fold (0.26 log units) below what was measured, within the range that was stated.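

In this assay, within the data shown here, carbamoyl in place of cyano on an aromatic carbon, para to a large group, gives the first step that can be read between compounds differing in one place: an at least 3.9-fold higher number from compound 3 to compound 4 (0.59 log units; beyond the scatter). With this change, compound 4 gives a number, 6.3 ug/mL, and not a limit, with the rest of the structure held constant. The true size of the step remains unknown and only its lower bound is fixed, because compound 3 gives a limit and not a number: the limit of < 1.6 ug/mL in this assay, at which 2 of the 4 values shown sit.

The compounds shown leave open whether this step is particular to carbamoyl or would also appear with another group at the same position, such as a sulfonamide, an amine or a methyl ester. They also leave open whether carbamoyl in place of cyano would give a step of similar size at another place on this ring, or on a different version of the shared core.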